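Swapping an aminophenyl for a pyridyl ring

The source may report more compounds than this note shows. Statements on the series, on what has been measured and on what is new or still open speak of the compounds shown alone.

Measured compounds:
- compound 1 `Cc1ncc([N+](=O)[O-])n1CCSc1nnc(-c2ccc(N)cc2)o1`: 6700 nM
- compound 2 `CCOc1ccc(-c2nnc(SCCn3c([N+](=O)[O-])cnc3C)o2)cc1`: 1900 nM
- compound 3 `COc1cc(-c2nnc(SCCn3c([N+](=O)[O-])cnc3C)o2)cc(OC)c1OC`: 14900 nM

All three were tested in a functional assay on HepG2 cells (Homo sapiens) for cytotoxicity, read by MTT assay, with a stated time of 48 h; a higher number here means a weaker inhibitor, a lower number a stronger inhibitor. Compound 1 stands second highest of the three numbers; its nearest neighbour is compound 3, whose value lies beyond the scatter above it, and the furthest is compound 2, whose value lies beyond the scatter below it.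

Compound 4 `Cc1ncc([N+](=O)[O-])n1CCSc1nnc(-c2ccncc2)o1` has not yet been measured. It differs from compound 1 in one place: pyridin-4-yl in place of 4-aminophenyl on an aromatic carbon

Within the data shown here, the only measured step that touches the same position is a 3.5-fold lower number from compound 1 to compound 2 (0.55 log units; beyond the scatter), where the amino group gave way to ethoxy. Among the measured compounds shown here, no measured pair shows an aryl ring replaced by a pyridine ring, and compound 3 merely shows that a more heavily substituted ring gives a higher number than compound 1. The data therefore give little reason to expect a move beyond the scatter in this assay, in either direction.

For compound 4 the expected value is 8000 nM, with a likely range from 3000 nM to 20000 nM. This estimate corresponds to the expected step of a 1.2-fold higher number from compound 1 to compound 4 (0.08 log units; within the scatter).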

Compound 4, half-maximal inhibitory concentration: 14800 nM
Compound 4: middle estimate off by 1.9-fold (0.27 log units), on the low side; the range from low to high includes it.
By their numbers in this assay, from the lowest: compound 2; then compound 1; then compounds 4 and 3 (each within the scatter of the next).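

In this assay, the step from 4-aminophenyl to pyridin-4-yl is a 2.2-fold higher number from compound 1 to compound 4 (0.34 log units; beyond the scatter), so replacing the aromatic ring itself, and not only the group it carries, moves the number beyond the scatter. Together with a 3.5-fold lower number from compound 1 to compound 2 (0.55 log units; beyond the scatter), this shows that changes at this aromatic carbon can shift the number in either direction from compound 1: ethoxy lowers it, while pyridin-4-yl raises it. No measurement shown here accounts for the size or direction of this step.

Compound 4 differs from compound 1 both by losing the amino group and by gaining a ring nitrogen, so the two changes cannot be separated here. A plain phenyl ring would isolate the loss of the amino group, and an aminopyridine ring would test the ring nitrogen with the amino group retained.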